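The source may report more compounds than this note shows. Statements on the series, on what has been measured and on what is new or still open speak of the compounds shown alone.

Compound 1 `Cc1cc(C)cc(/C=C(\C(=O)c2ccc(Cl)cc2)S(=O)(=O)c2ccc(Br)cc2)c1`: 10000 nM
Compound 2 `COc1ccc(/C=C(\C(=O)c2ccc(Cl)cc2)S(=O)(=O)c2ccc(Br)cc2)cc1`: 10000 nM
Compound 3 `COc1ccc(/C=C(\C(=O)c2ccc(Cl)cc2)S(=O)(=O)c2ccc(Br)cc2)cc1O`: 10000 nM

All three values come from a functional assay on DU-145 cells (Homo sapiens) for inhibition, read by trypan blue exclusion, with a stated time of 96 h; on this read-out higher numbers stand for weaker inhibition of growth and lower numbers for stronger inhibition of growth. Compound 3 stands level with compounds 1 and 2 at the digits shown: the step of no change at the digits printed from compound 1 to compound 3 (within the scatter) and the step of no change at the digits printed from compound 2 to compound 3 (within the scatter) both lie within the scatter, as does no change at the digits printed from compound 1 to compound 2 (within the scatter). Exchanging the aromatic group on the double-bonded chain carbon has so far not moved this assay at all.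

Compound 4 `O=C(/C(=C\c1ccc(Cl)cc1Cl)S(=O)(=O)c1ccc(Br)cc1)c1ccc(Cl)cc1` has not yet been measured in this assay. It differs from compound 3 in one place: 2,4-dichlorophenyl in place of 3-hydroxy-4-methoxyphenyl on a double-bonded chain carbon bound to a double-bonded chain carbon. Among the compounds with values here, no measured pair contains a 2,4-dichlorophenyl group, so no step bears directly on this change. What does bear on it is the pattern of the three measured steps, each an exchange of the group on that same carbon, and each came out within the scatter; compounds 1, 2 and 3 give no case of such an exchange that changed the read-out. On that basis the step of no change at the digits printed from compound 3 to compound 4 (within the scatter) is expected to be none beyond the scatter. Compound 4 is therefore estimated at 10000 nM, with a range from 4000 nM to 25000 nM.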

Compound 4, concentration for 50% growth inhibition: 50000 nM
Estimate against measurement, compound 4: 5.0-fold (0.70 log units) below, outside the stated range (above it).
By their numbers in this assay, from the lowest: compounds 1, 2 and 3 (each within the scatter of the next); then compound 4.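

In this assay the group on a double-bonded chain carbon bound to a double-bonded chain carbon now proves able to move the read-out: 2,4-dichlorophenyl gives a 5.0-fold higher number from compound 3 to compound 4 (0.70 log units; beyond the scatter) when it replaces 3-hydroxy-4-methoxyphenyl, a 5.0-fold higher number from compound 2 to compound 4 (0.70 log units; beyond the scatter) when it replaces 4-methoxyphenyl, and a 5.0-fold higher number from compound 1 to compound 4 (0.70 log units; beyond the scatter) when it replaces 3,5-dimethylphenyl. All three steps run the same way, so compound 4 is the weakest growth inhibitor of the four, and exchanges at this place are not always silent, even though the three earlier groups sat level with one another. Nothing measured here explains what about the 2,4-dichlorophenyl group produces this loss.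

The compounds shown leave open whether both chlorines are needed for this rise in the number, something a phenyl ring carrying only one chlorine could help to settle. They also leave open whether any group at this place, such as an aminophenyl or a carboxyphenyl, can bring the number below the level shared by compounds 1, 2 and 3.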